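The source may report more compounds than this note shows. Statements on the series, on what has been measured and on what is new or still open speak of the compounds shown alone.

Of the compounds shown here, three built on one shared core have been measured in a functional assay on isolated protein for inhibition of Glucose-dependent insulinotropic receptor (Rattus norvegicus), read by HTRF and cAMP accumulation; a lower number here means a smaller maximal response, a higher number a larger maximal response. Compound 1 `Cc1nc(S(C)(=O)=O)ccc1Oc1ncnc(OC2CCN(C(=O)OC(C)(C)C(F)(F)F)CC2)c1F` gives 79%, compound 2 `Cc1nc(S(C)(=O)=O)ccc1Oc1ncnc(OC2CCN(C(=O)O[C@@H](C)C(F)(F)F)CC2)c1F` gives 80%, and compound 3 `Cc1nc(S(C)(=O)=O)ccc1Oc1ncnc(OC2CCN(C(=O)SC3(C)CC3)CC2)c1F` gives 77%. Compound 3 stands at the lowest of the three numbers, yet its gaps to compound 1 and to compound 2 both lie within the scatter, so the three cannot be told apart. The measured steps were a number 1 percentage points higher from compound 1 to compound 2 (within the scatter), a number 2 percentage points lower from compound 1 to compound 3 (within the scatter) and a number 3 percentage points lower from compound 2 to compound 3 (within the scatter), each a change of the group on the carbonyl carbon or on an oxygen next to a carbonyl group, and none moved this assay beyond the scatter.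

Compound 4 `Cc1nc(S(C)(=O)=O)ccc1Oc1ncnc(OC2CCN(C(=S)OC3(C)CC3)CC2)c1F` differs from compound 3 in the same region: a group of 7 heavy atoms (5 carbon, 1 oxygen, 1 sulfur; one three-membered non-aromatic ring of carbon only) in place of a group of 7 heavy atoms (5 carbon, 1 oxygen, 1 sulfur; one three-membered non-aromatic ring of carbon only), on an amine nitrogen in a ring. Among the measured compounds shown here, no measured step swaps the oxygen and sulfur in this way, but every change made so far at this end of the molecule has left this assay unchanged beyond the scatter, so compound 4 is expected to show no step beyond the scatter, no change at the digits printed from compound 3 to compound 4 (within the scatter). Compound 4 is therefore estimated at 77%, with a range from 64% to 90%.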

Compound 4, largest response reached (reported as efficacy), in percent of the reference or control that the assay uses: 49%
Beside the measured number, compound 4's estimate is 28 percentage points above it, outside the stated range (below it).
By their numbers in this assay, from the lowest: compound 4; then compounds 3, 1 and 2 (each within the scatter of the next).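

In this assay the group on an amine nitrogen in a ring proves sensitive to how its atoms are joined: with the same atoms kept, trading the places of its oxygen and sulfur gives a clear fall (a number 28 percentage points lower from compound 3 to compound 4 (beyond the scatter)). Compound 4 also stands apart from the two compounds with fluorinated groups (a number 30 percentage points lower from compound 1 to compound 4 (beyond the scatter); a number 31 percentage points lower from compound 2 to compound 4 (beyond the scatter)), so the earlier flat results at this position do not hold for every change made there. Nothing shown here accounts for this fall.

Still open, as far as these compounds go, is whether the same swap would lower the number with a 1-(trifluoromethyl)ethyl group in place of the three-membered ring. Also open, from the compounds shown here alone, is where a urea or a plain amide on that nitrogen would fall.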